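The source may hold more compounds than are shown below. What is called first, only, known or untested is meant among the compounds shown, and "the series" means these compounds.

Measured compounds:
compound 1 `Cc1c(Nc2ccc(C#N)cc2Cl)ncnc1OC1CC2COCC(C1)N2C(=O)OC(C)(C)C`: 114 nM; 17 nM (2 entries)
compound 2 `COc1c(Nc2ccc(C#N)cc2F)ncnc1OC1C2COCC1CN(C(=O)OC1(C)CC1)C2`: 5 nM
compound 3 `Cc1c(Nc2ccc(S(C)(=O)=O)cc2Cl)ncnc1OC1CC2COCC(C1)N2C(=O)OC(C)(C)C`: 44 nM

In a functional assay on HEK293 cells for agonist activity at Glucose-dependent insulinotropic receptor (Homo sapiens), read by fluorescence and cAMP accumulation, with a stated time of 30 min (a lower number here means that less compound is needed, a higher number that more compound is needed for the effect), compound 2 gives 5 nM, the lowest of the two single numbers shown. Compound 3 gives 44 nM, and its gap from compound 2 lies beyond the scatter. Compound 1 has two entries, (the several entries of compound 1 in this assay, 114 nM; 17 nM (2 entries)), and so carries no single number. Compound 4 `COc1c(Nc2ccc(C#N)cc2Cl)ncnc1OC1C2COCC1CN(C(=O)OC1(C)CC1)C2` has not been measured. Compound 4 differs from compound 2 in one place: chloro in place of fluoro on an aromatic carbon. Among the compounds with values here, no pair of measured compounds isolates this change, so it has no measured precedent here. In this assay a small step is expected, most likely none beyond the scatter, leaning slightly toward a higher number. Compound 4 is therefore expected to give about 8 nM, within 2.5 nM to 25 nM. That estimate means an expected step of a 1.6-fold higher number from compound 2 to compound 4 (0.20 log units; within the scatter).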

Compound 4, half-maximal effective concentration: 7 nM
Estimate against measurement, compound 4: 1.1-fold (0.06 log units) above; measured number inside the range.
By their numbers in this assay, from the lowest: compounds 2 and 4 (each within the scatter of the next); then compound 3.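

In this assay, chloro in place of fluoro gives a 1.4-fold higher number from compound 2 to compound 4 (0.15 log units; within the scatter). Within the data shown here, this is the first matched pair at this aromatic carbon, ortho to a large group, and it shows that, on this core, compound 2 and compound 4 cannot be told apart. Nothing measured here offers a reason for this result. The compounds shown leave open whether a trifluoromethyl group or an amine would be tolerated on this same carbon. They also leave open whether fluoro and chloro would likewise match on the core of compound 1.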